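The source may hold more compounds than are shown below. What is called first, only, known or untested is meant among the compounds shown, and "the series" means these compounds.

Working notes on the series.

Three compounds have numbers in a functional assay on MDA-MB-231 cells (Homo sapiens) for inhibition, read by sulforhodamine B assay, with a stated time of 48 h; on this read-out lower numbers stand for stronger inhibition and higher numbers for weaker inhibition. Compound 1 `COc1ccc(C(c2ccccc2O)c2cccc3ccccc23)c(OC)c1OC` gives 17700 nM, the highest of the three. Compound 2 `COc1ccc(/C(=N/O)c2cccc3ccccc23)c(OC)c1OC` gives 2500 nM and compound 3 `C=C(c1ccc(OC)c(OC)c1OC)c1cccc2ccccc12` gives 4660 nM; both of these lie below compound 1 by more than the usual scatter, with compound 2 furthest from it and compound 3 nearest. Among the measured compounds shown here, no pair among the three differs in a single place, so no step between measured compounds is available.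

Compound 4 `COc1ccc(C(c2ccc(O)cc2)c2cccc3ccccc23)c(OC)c1OC` has not yet been measured in this assay. It differs from compound 1 as follows: 4-hydroxyphenyl in place of 2-hydroxyphenyl on a saturated chain carbon bound to two aromatic carbons. The two compounds hold the same atoms, joined differently.

Nothing measured bears directly on this kind of rearrangement of the hydroxyl on the phenyl ring, so the expectation rests on compound 1 alone. A small step toward a lower number, not beyond the scatter, is expected, so that the expected step from compound 1 to compound 4 is a 1.8-fold lower number from compound 1 to compound 4 (0.25 log units; within the scatter). Compound 4 is therefore estimated at 10000 nM, within a range of 3500 nM to 30000 nM.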

Compound 4, half-maximal inhibitory concentration: 17400 nM
Compound 4: the middle estimate sits 1.7-fold (0.24 log units) below what was measured; low and high end bracket the measured number.
By their numbers in this assay, from the lowest: compounds 2 and 3 (each within the scatter of the next); then compounds 4 and 1 (each within the scatter of the next).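

In this assay, 4-hydroxyphenyl in place of 2-hydroxyphenyl on a saturated chain carbon bound to two aromatic carbons gives a 1.0-fold lower number from compound 1 to compound 4 (0.01 log units; within the scatter), so the two arrangements of the same atoms cannot be told apart in this read-out. Among the compounds shown here, this is the first step that can be read in one place, and for this pair the location of the hydroxyl on the phenyl ring leaves the number within the scatter. Nothing available accounts for the two compounds reading alike.

On these data alone, whether the hydroxyl itself contributes at this carbon remains open, since a plain phenyl group would be needed to show it. Also open, as far as these compounds go, is whether a methoxy group, an amine or a carboxylic acid on that ring would separate from compound 1.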